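The source may report more compounds than this note shows. Statements on the series, on what has been measured and on what is new or still open speak of the compounds shown alone.

Among the measured compounds shown here, in a functional assay on HCT-15 cells (Homo sapiens) for inhibition, read by colorimetric assay and sulforhodamine B assay, with a stated time of 48 h (a higher number here means a weaker inhibitor of growth, a lower number a stronger inhibitor of growth), compound 2 `CCCCCCCCCCCC[C@@H](O)[C@H]1CC[C@H]([C@H](O)CCCCCCCCCCNC(=O)c2ccco2)O1` gives 100000 nM and holds the higher of the two numbers measured so far. For the measured compounds named here, compound 1 `CCCCCCCCCCCC[C@@H](O)[C@H]1CC[C@H]([C@H](O)CCCCCCCCCCNC(=O)c2cccs2)O1` gives 5750 nM in this assay and is the only compound to compare it with. The change now in question leads to compound 3 `CCCCCCCCCCCC[C@@H](O)[C@H]1CC[C@H]([C@H](O)CCCCCCCCCCNC(=O)c2ccoc2)O1` and reads furan-3-yl in place of furan-2-yl on a carbonyl carbon with furan-3-yl in place of furan-2-yl on a carbonyl carbon and the same atoms joined differently. Going by the values given here, only one measured step bears on this, and it is large and beyond the scatter: a 17-fold higher number from compound 1 to compound 2 (1.24 log units; beyond the scatter) for furan-2-yl in place of thiophen-2-yl. That step exchanges a different group, so it offers only loose guidance here. Set against a 17-fold higher number from compound 1 to compound 2 (1.24 log units; beyond the scatter) a smaller move toward a lower number is expected. The estimated step runs a 3.3-fold lower number from compound 2 to compound 3 (0.52 log units; beyond the scatter) in this expectation. For compound 3 the expected value is 30000 nM with an estimated range of 7000 nM to 100000 nM for this measurement.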

Compound 3, concentration for 50% growth inhibition: 100000 nM
Beside the measured number, compound 3's estimate is 3.3-fold (0.52 log units) below it; the measured number falls inside the stated range.
By their numbers in this assay, from the lowest: compound 1; then compounds 2 and 3 (each within the scatter of the next).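

On the carbonyl carbon whose other neighbour is the amide-type nitrogen, furan-3-yl in place of furan-2-yl gives no change at the digits printed from compound 2 to compound 3 (within the scatter) in this assay, so the two furan isomers cannot be told apart in this read-out. Furan-3-yl in place of thiophen-2-yl gives a 17-fold higher number from compound 1 to compound 3 (1.24 log units; beyond the scatter), a step that matches a 17-fold higher number from compound 1 to compound 2 (1.24 log units; beyond the scatter), so the gap seen earlier is not particular to furan-2-yl but holds for both furans against thiophen-2-yl among these three compounds. Nothing shown here accounts for that gap.

The compounds shown leave open where thiophen-3-yl would fall on this carbonyl carbon, and so whether the thiophene's attachment point matters as little as the furan's did. They also leave open how a phenyl or a pyridin-3-yl group would read there.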